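From 3-bromo-4-methoxyphenyl to 4-fluoro-3-methylphenyl

This account rests on a few compounds, and the source may have more. Where it says the series, first, only, none or still open, it means among the compounds named here.

Of the compounds shown here, two on a shared core have been tested so far. Compound 1 `COc1ccc(C2=C(c3cc(OC)c(OC)c(OC)c3)CC3CCCN3C2=O)cc1O` returned > 100000 nM in a functional assay on SW-620 cells (Homo sapiens) for cytotoxicity (a lower number here means a stronger inhibitor of growth, a higher number a weaker inhibitor of growth), and this is a limit of the assay, not a number. Among the compounds with values here, compound 2 `COc1ccc(C2=C(c3ccc(SC)cc3)CC3CCCN3C2=O)cc1Br` gave 5000 nM and so holds the only true number available. Within the data shown here, no two measured compounds differ in one place alone, so the size of a single change cannot be read from the data.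

Compound 3 `CSc1ccc(C2=C(c3ccc(F)c(C)c3)C(=O)N3CCCC3C2)cc1` keeps the 4-(methylsulfanyl)phenyl group of compound 2 but carries 4-fluoro-3-methylphenyl in place of 3-bromo-4-methoxyphenyl on a double-bonded ring carbon. With compound 2 at 5000 nM as the sole anchor, a moderate loss of growth inhibition is expected in this assay rather than a gain, although a result within the scatter would be no surprise. The expected size of the change is a 2.4-fold higher number from compound 2 to compound 3 (0.38 log units; beyond the scatter) in this estimate. The estimated value for compound 3 is 12000 nM with an expected range from 3000 nM to 60000 nM in this measurement.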

Compound 3, concentration for 50% growth inhibition: 600 nM
Compound 3: middle estimate off by 20-fold (1.30 log units), on the high side; measured number below the stated range.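

In this assay, within the data shown here, the change from 3-bromo-4-methoxyphenyl to 4-fluoro-3-methylphenyl gives an 8.3-fold lower number from compound 2 to compound 3 (0.92 log units; beyond the scatter), and this is the first single change on the shared core whose size can be read. It shows that, with the 4-(methylsulfanyl)phenyl group held fixed, growth inhibition responds to the group on this double-bonded ring carbon, and that the response goes towards a lower number when these two substituted phenyl groups are exchanged. Compound 1 adds no step, since it differs from the other two compounds in more than one place and its entry is a limit of the assay: the limit of > 100000 nM in this assay, at which 1 of the 3 values shown sits.

Because the bromine, methoxy, fluorine and methyl substituents all change together in this one step, the data do not tell which of them accounts for it, and a group such as 3-bromo-4-methylphenyl would help to separate them. Also open, going by these compounds, is how the number would respond to a group of another kind at this ring carbon, such as an aminophenyl or a carboxyphenyl group, or to a longer chain in place of the methyl group of 4-fluoro-3-methylphenyl.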